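A few compounds are considered here, and "the series" means these few. Any claim that something is new, unique, unknown or untested is made for them only; others in the source may bear on it.

In a functional assay on MCF7 cells (Homo sapiens) for antiproliferative activity, read by MTT assay, with a stated time of 72 h (on this read-out lower numbers stand for stronger inhibition and higher numbers for weaker inhibition), compound 1 (`O=C(N/N=C/c1ccc(F)cc1)Nc1ccc(Oc2ccnc3[nH]ccc23)c(F)c1`) gives 800 nM and compound 3 (`COc1ccc(/C=N/NC(=O)Nc2ccc(Oc3ccnc4[nH]ccc34)c(F)c2)c(OC)c1OC`) gives 134 nM. Compound 2 (`O=C(N/N=C/c1cccc(Cl)c1Cl)Nc1ccc(Oc2ccnc3[nH]ccc23)c(F)c1`) has no number at all: it is reported as "not active" (no number reported), so it cannot be placed on the scale beside the other two. Compound 4 (`O=C(N/N=C/c1cc(Br)c(O)c(Br)c1)Nc1ccc(Oc2ccnc3[nH]ccc23)c(F)c1`) has 3,5-dibromo-4-hydroxyphenyl in place of 2,3-dichlorophenyl on a carbon with a double bond to nitrogen. With no number for compound 2, the size of this step cannot be stated. The expected direction in this assay is toward stronger inhibition, from no reported activity to a measurable value, as seen for compound 1 at 800 nM. A result without a number remains possible, as compound 2 shows. The estimated value for compound 4 is 600 nM, with an expected range of 100 nM to 4000 nM.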

Compound 4, half-maximal inhibitory concentration: "not active" (no number reported)
The entry for compound 4 holds no number; the estimate stays without a comparison.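

Compound 4, like compound 2, is reported as "not active" without a number in this assay, so no step can be read between them. No measured evidence bears on this result. The compounds shown leave open how far apart compound 2 and compound 4 actually lie.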